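The source may report more compounds than this note shows. Statements on the series, on what has been measured and on what is new or still open speak of the compounds shown alone.

Measured so far:
compound 1 `CC1=C(C(=O)OC(C)(C)C)C(c2ccoc2)NC(=O)N1`: in an assay on membranes from HeLa cells for displacement of a labelled ligand from adenosine receptor A3 (Homo sapiens), read by scintillation counting, with a stated time of 180 min, tested at 1 uM (on this read-out lower numbers stand for less inhibition and higher numbers for more inhibition at the one concentration tested (going by the name of the read-out)), compound 1 gives 2%
compound 2 `COC(=O)C1=C(C)NC(=O)NC1c1cccs1`: in this assay compound 2 gives 3%

Compound 2 gives the higher of the two numbers, yet compound 1 lies within the scatter of it, so the two compounds show no difference. Compound 3 `CC1=C(C(=O)OC(C)(C)C)C(c2cccs2)NC(=O)N1` carries one change from compound 2: tert-butyl in place of methyl on an oxygen next to a carbonyl group. Among the compounds with values here, no step between measured compounds is known. The step of no change at the digits printed from compound 2 to compound 3 (within the scatter) is expected to be none beyond the scatter, because compound 1 already bears tert-butyl and gives 2%. Compound 3 is therefore estimated at 3%, with a range from -8% to 14%.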

Compound 3, a percentage reported as inhibition, at one concentration (the size of the read-out at that concentration, not a potency): 7%
Compound 3: the middle estimate sits 4 percentage points below what was measured; measured number inside the range.
By their numbers in this assay, from the lowest: compounds 1, 2 and 3 (each within the scatter of the next).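

In this assay the step of a number 4 percentage points higher from compound 2 to compound 3 (within the scatter) comes with tert-butyl in place of methyl on an oxygen next to a carbonyl group, so the two groups cannot be told apart at this place when thiophen-2-yl is held fixed. The step of a number 5 percentage points higher from compound 1 to compound 3 (within the scatter) comes with thiophen-2-yl in place of furan-3-yl on a saturated ring carbon, so with tert-butyl held fixed these two rings cannot be told apart either. No measurement on these compounds offers a reason for these readings.

Open, on these data alone, is whether a benzyl group on that oxygen, or a phenyl ring on the saturated ring carbon, would give a number beyond the scatter.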